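This account rests on a few compounds, and the source may have more. Where it says the series, first, only, none or still open, it means among the compounds named here.

Measured compounds:
Compound 1, `Cc1cc(O)cc(-c2nn(CC#N)cc2-c2ccnc(-c3ccc(Oc4ccccc4)cc3)c2)c1`: 102%
Compound 2, `COc1cc(C)cc(-c2nn(CC#N)cc2-c2ccnc(-c3ccc(N(C)C)cc3)c2)c1`: 50%

Of the compounds shown here, two have been tested in a functional assay on TK-10 cells (Homo sapiens) for cytotoxicity, read by sulforhodamine B assay, with a stated time of 48 h, tested at 100 nM; on this read-out lower numbers stand for a stronger effect and higher numbers for a weaker effect at the one concentration tested. Compound 1 gives 102% in this assay, while compound 2 gives 50%, the lower of the two numbers, and the gap between them lies beyond the scatter. The two differ in more than one place, so only their values can be compared.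

Compound 3, `Cc1cc(O)cc(-c2nn(CC#N)cc2-c2ccnc(-c3ccc(N(C)C)cc3)c2)c1`, has not yet been measured. It differs from compound 2 in a single spot: hydrogen in place of methyl on an oxygen on an aromatic ring. Among the compounds with values here, no pair of measured compounds shows this change alone, so no measured step guides the expectation. Compound 3 is therefore expected to stay close to compound 2, with the estimated step of a number 8 percentage points higher from compound 2 to compound 3 (within the scatter) expected to fall within or just beyond the scatter. In this assay compound 3 is estimated to give 58%, between 32% and 88%.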

Compound 3, a percentage reported as activity, at one concentration (the size of the read-out at that concentration, not a potency): 125%
For compound 3 the middle estimate is 67 percentage points below the measured one; the measured number lies above the stated range.
By their numbers in this assay, from the lowest: compound 2; then compound 1; then compound 3.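

In this assay, the change from methoxy to hydroxy on the 3-methoxy-5-methylphenyl group is a large one, a number 75 percentage points higher from compound 2 to compound 3 (beyond the scatter), so the methyl on this oxygen matters greatly for the read-out, and its removal takes away the effect seen for compound 2 at 50%. With hydroxy held constant, the other change gives a number 23 percentage points higher from compound 1 to compound 3 (beyond the scatter), so dimethylamino in place of phenoxy does not by itself bring a stronger effect and the low number of compound 2 appears only alongside the methoxy. No measurement given here bears on why the methyl has such an effect.

The compounds shown leave open how an ethoxy group or an amine would read on this ring, and whether phenoxy combined with methoxy would also give a low number. From the compounds shown here alone, all of these readings come from a single concentration, so they show only a stronger or weaker effect at that concentration, and how the compounds compare at other concentrations remains open.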